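From 2-oxopyrrolidin-1-yl to 2-methoxyphenyl on a shared core

The source may report more compounds than this note shows. Statements on the series, on what has been measured and on what is new or still open speak of the compounds shown alone.

Compound 1 `Cc1n[nH]c(-c2ncc3c(NCc4ccc(Cl)cc4)ccnc3c2O)n1`: > 50100 nM
Compound 2 `Cc1n[nH]c(-c2ncc3c(N4CCCC4=O)ccnc3c2O)n1`: > 50100 nM

Both entries come from a toxicity assay on THP-1 cells (Homo sapiens) for cytotoxicity (on this read-out higher numbers stand for an effect only at larger amounts of compound and lower numbers for an effect already at smaller amounts), and each is a limit of the assay rather than a number. Compound 2 stands at the limit of > 50100 nM in this assay, at which 2 of the 2 values shown sit. Compound 3 `COc1ccccc1-c1ccnc2c(O)c(-c3nc(C)n[nH]3)ncc12` keeps the core of compound 2 and differs from it in one place: 2-methoxyphenyl in place of 2-oxopyrrolidin-1-yl on an aromatic carbon. In plain terms, 2-methoxyphenyl sits in place of 2-oxopyrrolidin-1-yl on an aromatic carbon. Going by the values given here, no measured step between two compounds is available to size this change. Compound 1, which carries yet another group at that place, also gives a limit, > 50100 nM. No change beyond the usual scatter is therefore expected in this assay. The estimated change is an at least 1.1-fold lower number from compound 2 to compound 3 (0.04 log units; that floor lies within the scatter). For compound 3 the expected value is 45000 nM, within an estimated range from 15000 nM to 50100 nM.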

Compound 3, half-maximal effective concentration: > 50100 nM
Compound 3: a limit, no number (the forecaster's own chance of this, stated with the estimate: 75%); at least 1.1-fold (0.04 log units) between middle value and limit.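

Compound 2 and compound 3 each give only a limit in this assay, so no step between them can be read: the limit of > 50100 nM in this assay, at which 3 of the 3 values shown sit.

The compounds shown leave open whether 2-methoxyphenyl in place of 2-oxopyrrolidin-1-yl changes anything in this assay, and at what amount any of the three compounds would show an effect.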